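The source may report more compounds than this note shows. Statements on the series, on what has been measured and on what is new or still open speak of the compounds shown alone.

Two members of this series carry a reading in an assay on membranes from CHO cells for displacement of a labelled ligand from adenosine receptor A1 (Homo sapiens), read by scintillation counting, with a stated time of 60 min, tested at 1 uM; a lower number here means less inhibition, a higher number more inhibition at the concentration tested (going by the name of the read-out). Compound 1 `CC1=C(C(=O)OC(C)(C)C)C(c2ccoc2)NC(=O)N1` gives 11% in this assay. Compound 2 `CC1=C(C(=O)OC(C)C)[C@H](c2ccco2)NC(=S)N1` gives 10% in this assay; this is the lower of the two numbers, but compound 1 sits within the scatter of it, so no order between the two can be drawn and both numbers are low at the concentration tested.

Compound 3 `CC1=C(C(=O)OC(C)C)[C@@H](c2ccco2)NC(=S)N1` has not been measured in this assay. Relative to compound 2 it shows the following: the two compounds have the same atoms and bonds and differ only in configuration as drawn: 1 of 1 stereo elements differ; a stereocentre at a saturated ring carbon is drawn R in compound 2 and S in compound 3. For the measured compounds named here, no pair of measured compounds in this set differs in one place, so no measured step of any kind is available for comparison, and in particular nothing is known here about how a change of configuration at this centre affects the reading.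

Given that compound 2 gives only 10% and compound 1 only 11%, the step is expected to stay within the scatter, with the expected change being a number 2 percentage points higher from compound 2 to compound 3 (within the scatter), in no clear direction. For compound 3 the estimated value in this assay is 12%, expected to fall between 0% and 30%.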

Compound 3, a percentage reported as inhibition, at one concentration (the size of the read-out at that concentration, not a potency): 8%
Estimate against measurement, compound 3: 4 percentage points above; the range from low to high includes it.
By their numbers in this assay, from the lowest: compounds 3, 2 and 1 (each within the scatter of the next).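

For the compounds shown here, the first step in one place in this set reads, in this assay, a number 2 percentage points lower from compound 2 to compound 3 (within the scatter), with the stereocentre at the saturated ring carbon drawn R in the first compound and S in the second. This step can be assigned to that centre alone, because no atom or bond changes, as the structures show: the fact that compounds 2 and 3 differ only in the configuration as drawn
On this evidence, inverting this centre does not move the reading beyond the scatter for this pair, which is a finding about these two compounds only and not about the series.

From the compounds shown here alone, all the readings so far are low at the one concentration tested, so it remains open whether the two configurations would separate in a compound with a clearly higher reading. Also open, going by these compounds, is how the reading at this centre would respond to a different group on the same ring carbon, such as an amine or a carboxylic acid, or to a longer chain in place of the ester, and whether the R and S forms would then part.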